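Compound 3 to compound 4: chloro in place of fluoro

The compounds below may be only part of what the source reports. "The series", "measured", "known", "first", "only" and "open" are said of these compounds alone.

In an ADME assay (liver, Mus musculus) for metabolic stability, using microsomes (a lower number here means that the compound disappears faster, a higher number that the compound lasts longer), compound 3 (`CCc1nc2cc(Cl)ccn2c1C(=O)NCc1ccc(N2CCC(c3ccc(F)cc3)CC2)cc1`) stands highest of the three measured compounds with 0.307 h while compound 2 (`CCc1nc2cc(Cl)ccn2c1C(=O)NCc1ccc(N2CCC(Cl)CC2)cc1`) gives 0.0867 h and compound 1 (`CCc1nc2cc(Cl)ccn2c1C(=O)NCc1ccc(N2CCCCC2)cc1`) gives 0.0383 h as its half-life. Compound 4 (`CCc1nc2cc(Cl)ccn2c1C(=O)NCc1ccc(N2CCC(c3ccc(Cl)cc3)CC2)cc1`) differs from compound 3 by chloro in place of fluoro on an aromatic carbon as chloro in place of fluoro on an aromatic carbon. The measured steps are a 2.3-fold higher number from compound 1 to compound 2 (0.35 log units; beyond the scatter) and an 8.0-fold higher number from compound 1 to compound 3 (0.90 log units; beyond the scatter) and a 3.5-fold higher number from compound 2 to compound 3 (0.55 log units; beyond the scatter) on a saturated ring carbon. For the measured compounds named here, all lie beyond the scatter, but none changes a group on an aromatic carbon, so they offer no direct precedent. No step beyond the scatter is expected in this assay and the estimated move is a 1.0-fold lower number from compound 3 to compound 4 (0.01 log units; within the scatter) here. For compound 4 the expected half-life is 0.3 h with an estimated range of 0.15 h to 0.6 h in this series.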

Compound 4, half-life: 1.87 h
Compound 4: the middle estimate sits 6.2-fold (0.79 log units) below what was measured; measured number outside the range, above it.
By their numbers in this assay, from the lowest: compound 1; then compound 2; then compound 3; then compound 4.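

In this assay the aromatic carbon para to a large group proves sensitive: a 6.1-fold higher number from compound 3 to compound 4 (0.78 log units; beyond the scatter) for the exchange of a single heavy atom, chloro in place of fluoro. Set against the saturated ring carbon, 4-chlorophenyl gives a 22-fold higher number from compound 2 to compound 4 (1.33 log units; beyond the scatter) and a 49-fold higher number from compound 1 to compound 4 (1.69 log units; beyond the scatter) so the identity of the group on the aromatic ring, not only the presence of that ring, shapes the half-life here. No measured evidence on the reason for this step is available.

As far as these compounds go, whether bromo, methyl, trifluoromethyl or methoxy at this place would follow chloro remains open.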